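The compounds below may be only part of what the source reports. "The series", "measured", "known", "first", "only" and "open" are said of these compounds alone.

Compound 1 `CCCCCCN1CCC(C(=O)Nc2cc(Cl)c(N)cc2OC)CC1` carries a pentyl on a saturated chain carbon bound to an amine nitrogen in a ring. In a functional assay on the whole organism for antagonist activity, with Mus musculus as the target (on this read-out higher numbers stand for an effect only at larger amounts of compound and lower numbers for an effect already at smaller amounts), compound 1 gives only a limit, > 10 mg/kg. Compound 2 `COc1cc(N)c(Cl)cc1NC(=O)C1CCN(Cc2ccccc2Cl)CC1` likewise gives only a limit, > 4 mg/kg. Compound 3 `COc1ccc(CN2CCC(C(=O)Nc3cc(Cl)c(N)cc3OC)CC2)cc1` gives 0.9 mg/kg. The step of an at least 11-fold lower number from compound 1 to compound 3 (1.04 log units; beyond the scatter) is large, the step of an at least 4.4-fold lower number from compound 2 to compound 3 (0.64 log units; beyond the scatter) is at least modest, and the step that the two limits leave unreadable from compound 1 to compound 2 cannot be read. Compound 4 `COc1cc(N)c(Cl)cc1NC(=O)C1CCN(CC2CCCC2)CC1` differs from compound 1 by cyclopentyl in place of pentyl on a saturated chain carbon bound to an amine nitrogen in a ring. Both readable steps set 4-methoxyphenyl in place of pentyl or 2-chlorophenyl, which is not the change here, so they bear on it only loosely. A step of an at least 1.2-fold lower number from compound 1 to compound 4 (0.09 log units; that floor lies within the scatter) is expected. Compound 4 is therefore estimated at 8 mg/kg, between 2 mg/kg and 30 mg/kg.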

Compound 4, dose for half-maximal effect: > 10 mg/kg
Compound 4 ended at the assay's limit; the forecaster's own chance of this, stated with the estimate: 50%; middle value at least 1.2-fold (0.09 log units) away from the limit.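

In this assay compound 4 gives only a limit, the same one as compound 1: the limit of > 10 mg/kg in this assay, at which 2 of the 4 values shown sit. Among the groups shown at this place, only 4-methoxyphenyl gives a number rather than a limit, and cyclopentyl in its place yields an at least 11-fold higher number from compound 3 to compound 4 (1.04 log units; beyond the scatter) in the comparison with that number. The steps to compound 4 from compound 1 and compound 2 cannot be read, since both ends are limits.

Pentyl and cyclopentyl therefore cannot be ordered. On these data alone, whether 4-hydroxyphenyl or 4-methylphenyl at this place would match compound 3 stays open.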